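Swapping the Sulfonyl Aryl Group: Hydroxyl for Chlorine

The source may report more compounds than this note shows. Statements on the series, on what has been measured and on what is new or still open speak of the compounds shown alone.

Of the compounds shown here, three sharing one core have been measured in an assay on cells for inhibition of HSP60/HSP10 (Homo sapiens), with a stated time of 60 min; a higher number here means a weaker inhibitor, a lower number a stronger inhibitor. Compound 1 `O=S(=O)(Nc1ccc(-c2nc3ccccc3o2)cc1)c1cccs1` gives 63000 nM. Compound 3 `O=S(=O)(Nc1ccc(-c2nc3ccccc3o2)cc1)c1cccc(Cl)c1` gives 54000 nM, which is the lowest of the two numbers, though a 1.2-fold lower number from compound 1 to compound 3 (0.07 log units; within the scatter), so compounds 1 and 3 cannot be told apart. Compound 2 `O=S(=O)(Nc1ccc2oc(-c3ccccc3)nc2c1)c1ccc(Cl)c(Cl)c1` carries the sulfonamide on a different ring and returns only a limit of the assay, > 100000 nM; as noted, (the limit of > 100000 nM in this assay, at which 1 of the 3 values shown sits).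

Compound 4 `O=S(=O)(Nc1ccc(-c2nc3ccccc3o2)cc1)c1ccccc1O` is not yet measured. It differs from compound 3 in one place: 2-hydroxyphenyl in place of 3-chlorophenyl on a sulfonyl sulfur.

Among the compounds with values here, only one measured step touches the same sulfonyl sulfur, and it was a 1.2-fold lower number from compound 1 to compound 3 (0.07 log units; within the scatter), which lies within the scatter of repeated measurements. Within the data shown here, nothing measured so far speaks to a hydroxyl on that ring, so the change from compound 3 to compound 4 is expected to give no step beyond the scatter in this assay, and a result near the limit of the assay cannot be ruled out. The expected step is a 1.1-fold higher number from compound 3 to compound 4 (0.05 log units; within the scatter). Compound 4 is therefore estimated at 60000 nM in this assay, with a range from 25000 nM to 150000 nM.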

Compound 4, half-maximal inhibitory concentration: > 100000 nM
Compound 4 gave a limit, no number; the forecaster's own chance of this, stated with the estimate: 30%; middle value at least 1.6-fold (0.22 log units) from the limit.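

In this assay, compound 4 returns only a limit of the assay, > 100000 nM, so this sulfonyl sulfur now carries a group, 2-hydroxyphenyl, that yields no actual number on this core. Both new steps are floors rather than full sizes, with an at least 1.8-fold higher number from compound 3 to compound 4 (0.26 log units; that floor lies within the scatter) and an at least 1.5-fold higher number from compound 1 to compound 4 (0.20 log units; that floor lies within the scatter); neither floor clears the scatter, so a real loss is not established, although neither step points towards a stronger inhibitor. Thiophen-2-yl and 3-chlorophenyl could not be told apart at this position, whereas the 2-hydroxyphenyl swap is the first change here that may weaken the compound, and the readings are gathering at one end of what can be reported: the limit of > 100000 nM in this assay, at which 2 of the 4 values shown sit.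

The compounds shown do not separate the contribution of the added hydroxyl from that of the lost chlorine, and the true size of either step remains unknown. On these data alone, how a plain phenyl ring, or a ring bearing an amine or a carboxylic acid, would read at this sulfonyl sulfur also remains open.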